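Alkyl chain extension at the propargylic carbon

The source may report more compounds than this note shows. Statements on the series, on what has been measured and on what is new or still open speak of the compounds shown alone.

Measured so far:
- compound 1 `COC(=O)C#CC(CC(C)C)O/C=C/C(=O)OC`: 380 nM
- compound 2 `COC(=O)C#CC(O/C=C/C(=O)OC)C(C)C`: 750 nM
- compound 3 `CCCCC(C#CC(=O)OC)O/C=C/C(=O)OC`: 240 nM

In a functional assay on SW1573 cells (Homo sapiens) for antiproliferative activity, read by sulforhodamine B assay, with a stated time of 48 h (a higher number here means a weaker inhibitor of growth, a lower number a stronger inhibitor of growth), compound 3 stands lowest of the three numbers; compound 1 is nearest, as a 1.6-fold lower number from compound 1 to compound 3 (0.20 log units; within the scatter) shows, and compound 2 is furthest, as a 3.1-fold lower number from compound 2 to compound 3 (0.49 log units; beyond the scatter) shows. Compound 4 `CCCCCCC(C#CC(=O)OC)O/C=C/C(=O)OC` is not yet measured in this assay. It differs from compound 3 as follows: ethyl in place of hydrogen on a saturated chain carbon, five bonds along the chain from an oxygen on an unsaturated carbon and a triple-bonded carbon. The step that bears on this is a 3.1-fold lower number from compound 2 to compound 3 (0.49 log units; beyond the scatter), where a longer chain at that carbon gave a lower number; a 2.0-fold higher number from compound 1 to compound 2 (0.30 log units; within the scatter) and a 1.6-fold lower number from compound 1 to compound 3 (0.20 log units; within the scatter) stayed within the scatter. Nothing here tests a chain longer than butyl at this carbon, so the expected step of a 1.3-fold lower number from compound 3 to compound 4 (0.12 log units; within the scatter) is small: a lower number in this assay is possible, but the step may well fall within the scatter. For compound 4 the estimated value in this assay is 180 nM, in the range 80 nM to 450 nM.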

Compound 4, concentration for 50% growth inhibition: 3300 nM
Beside the measured number, compound 4's estimate is 18-fold (1.26 log units) below it; the measured number lies above the stated range.
By their numbers in this assay, from the lowest: compounds 3, 1 and 2 (each within the scatter of the next, the first and the last beyond it); then compound 4.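

In this assay the gain seen on going to a butyl chain does not continue: the hexyl chain reverses it (a 14-fold higher number from compound 3 to compound 4 (1.14 log units; beyond the scatter)). The branched chains also give lower numbers than hexyl (a 4.4-fold higher number from compound 2 to compound 4 (0.64 log units; beyond the scatter); an 8.7-fold higher number from compound 1 to compound 4 (0.94 log units; beyond the scatter)), so compound 4 is the weakest of the four compounds shown, and the numbers do not fall steadily as the chain at this carbon grows. No measurement on hand explains this reversal.

On these data alone, it remains open whether the loss already sets in with a pentyl chain, or goes further with an octyl chain. Also open, as far as these compounds go, is whether a hydroxyl group or an amine at the end of the hexyl chain would bring the number back down.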